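This account rests on a few compounds, and the source may have more. Where it says the series, first, only, none or still open, it means among the compounds named here.

Of the compounds shown here, two built on one shared core have been measured in a functional assay on HeLa cells (Homo sapiens) for cytotoxicity, read by WST assay, with a stated time of 48 h; on this read-out lower numbers stand for stronger inhibition and higher numbers for weaker inhibition. Compound 1 `COC[C@H](C)[C@@H](C)C(c1ccc(O)c(OC)c1)c1ccc(O)c(OC)c1` gives 77000 nM, while compound 2 `COc1cc(C(c2ccc(O)c(OC)c2)[C@H](C)[C@@H](C)CF)ccc1O` gives 34000 nM, the lower of the two numbers. Compound 3 `COC[C@@H](C)[C@H](C)C(c1ccc(O)c(OC)c1)c1ccc(O)c(OC)c1` has not yet been measured. It carries 2-(methoxymethyl)-1-methylpropyl in place of the 2-(fluoromethyl)-1-methylpropyl of compound 2, on a saturated chain carbon bound to two aromatic carbons (2-(methoxymethyl)-1-methylpropyl in place of 2-(fluoromethyl)-1-methylpropyl on a saturated chain carbon bound to two aromatic carbons). For the measured compounds named here, the group is the one found in compound 1, but with its stereocentres inverted, and no measured pair shows what that inversion does. Going by the values given here, the only measured step is modest: a 2.3-fold lower number from compound 1 to compound 2 (0.36 log units; beyond the scatter). The new change runs roughly the opposite way, so a higher number of similar size is expected in this assay, with wide uncertainty. The expected change is a 1.8-fold higher number from compound 2 to compound 3 (0.25 log units; within the scatter). Compound 3 is estimated at 60000 nM, within an expected range of 25000 nM to 130000 nM.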

Compound 3, half-maximal inhibitory concentration: 58000 nM
Estimate against measurement, compound 3: 1.0-fold (0.01 log units) above; the measured number falls inside the stated range.
By their numbers in this assay, from the lowest: compounds 2, 3 and 1 (each within the scatter of the next, the first and the last beyond it).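

In this assay, inverting both stereocentres gives a 1.3-fold lower number from compound 1 to compound 3 (0.12 log units; within the scatter), so the mirror-image change at this position has no effect that can be told from the scatter. Exchanging the fluoromethyl end of the chain for methoxymethyl gives a 1.7-fold higher number from compound 2 to compound 3 (0.23 log units; within the scatter), which also stays inside the scatter, even though compound 1 and compound 2, the two ends of this short series, lie beyond it. For the compounds shown here, the first of these readings isolates handedness, which the earlier compounds could not do, and its basis is simple: the fact that compounds 1 and 3 differ only in the configuration as drawn.

As far as these compounds go, whether the fluorinated chain would respond to the same inversion as the methoxy chain stays open. So does what a hydroxymethyl or an aminomethyl group would give on this chain, in either configuration.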